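Isobutyl for Isopropyl in a Series That Shows Only Limits

A few compounds are considered here, and "the series" means these few. Any claim that something is new, unique, unknown or untested is made for them only; others in the source may bear on it.

Three compounds were examined in a functional assay on MRC5 cells (Homo sapiens) for inhibition, read by microscopy and resazurin assay, with a stated time of 72 h; a higher number here means a weaker inhibitor, a lower number a stronger inhibitor. Compound 1 `C=CCONC(=O)CN1C(=O)S/C(=C\c2ccc(C(=O)N[C@@H](CC(C)C)C(=O)OC)cc2)C1=O` was reported at > 128000 nM, which is a limit of the assay and not a number. Compound 2 `C=CCONC(=O)CN1C(=O)S/C(=C\c2ccc(C(=O)N[C@H](C(=O)OC)C(C)C)cc2)C1=O` likewise returned only a limit, > 128000 nM. Compound 3 `CC(C)[C@H](NC(=O)CNC(=O)c1cn(CC(=O)NOCc2ccccc2)c2ccccc12)C(=O)O` too was reported as a limit, > 128000 nM. Compound 2 and compound 1 differ by isobutyl in place of isopropyl on a saturated chain carbon bound to an amide-type nitrogen and a carbonyl carbon; the step that the two limits leave unreadable from compound 2 to compound 1 cannot be sized because the limit of > 128000 nM in this assay, at which 3 of the 3 values shown sit, covers both ends of it. How the core of compound 3 differs from that of compound 2 is not broken down here.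

Compound 4 `CC(C)C[C@H](NC(=O)CNC(=O)c1cn(CC(=O)NOCc2ccccc2)c2ccccc12)C(=O)O` has not been measured. It differs from compound 3 by isobutyl in place of isopropyl on a saturated chain carbon bound to an amide-type nitrogen and a carbonyl carbon, the same change as that between compound 2 and compound 1. Since that earlier change left no readable step, and compound 3 itself stands only at the limit > 128000 nM, compound 4 is expected in this assay near 150000 nM, within 60000 nM to 400000 nM. This expectation amounts to a step that the limit leaves unreadable from compound 3 to compound 4, and most probably the assay will again report only a limit.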

Compound 4, half-maximal inhibitory concentration: > 128000 nM
Compound 4: a limit, no number; the forecaster's own chance of this, stated with the estimate: 90%; the middle value does not contradict the limit.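

The result for compound 4 in this assay is a limit and not a number, as is that of compound 3, so no step can be read for isobutyl in place of isopropyl, because both ends rest on one limit: the limit of > 128000 nM in this assay, at which 4 of the 4 values shown sit.

The compounds shown leave open whether this change alters inhibition in this assay at all.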